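Series notes: one substituent swap on the aromatic nitrogen

The source may report more compounds than this note shows. Statements on the series, on what has been measured and on what is new or still open speak of the compounds shown alone.

Of the compounds shown here, three have been measured in a functional assay on HeLa cells (Homo sapiens) for inhibition, read by MTT assay, with a stated time of 24 h; on this read-out higher numbers stand for weaker inhibition and lower numbers for stronger inhibition. Compound 1 `CCOC(=O)C1=Cc2ccccc2OC1(OCc1cc(-c2ccc(OC)cc2)no1)C(F)(F)F` stops at the limit of the assay, giving > 150000 nM. Compound 2 `CCOC(=O)C1=Cc2ccccc2OC1(OCc1cn(CC(=O)Nc2cccc(F)c2)nn1)C(F)(F)F` likewise reaches only the limit, at > 150000 nM. Compound 3 `O=C(O)C1=Cc2ccccc2OC1(OCc1cc(-c2ccc3ccccc3c2)no1)C(F)(F)F` also returns the limit, > 150000 nM. Among the compounds with values here, compound 2 therefore stands exactly where every measured member stands, since (the limit of > 150000 nM in this assay, at which 3 of the 3 values shown sit); no numerical value separates it from compound 1 or compound 3, and no step between measured compounds can be sized.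

Compound 4 `CCOC(=O)C1=Cc2ccccc2OC1(OCc1cn(-c2ccc([N+](=O)[O-])cc2)nn1)C(F)(F)F` has not yet been measured. It differs from compound 2 in one place: 4-nitrophenyl in place of ((3-fluorophenyl)carbamoyl)methyl on an aromatic nitrogen. Within the data shown here, no measured pair shows what such a change does in this assay. With every measured value sitting at the limit, no change beyond the scatter is expected, and the estimated step of a number no higher from compound 2 to compound 4 (the limit leaves the size open) is set accordingly. Compound 4 is expected to give about 150000 nM, with a range from 70000 nM to 320000 nM, most likely reported again only as a limit.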

Compound 4, half-maximal inhibitory concentration: > 150000 nM
Compound 4: only a limit was reported; the forecaster's own chance of this, stated with the estimate: 80%; the middle value lies on the limit itself.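

In this assay compound 4 gives > 150000 nM, a limit of the assay. Within the data shown here, compound 2 gives > 150000 nM, also a limit, so no step between compound 2 and compound 4 can be read. The compounds shown leave open whether any substituent on the aromatic nitrogen gives a measurable inhibition value.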